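Pyrazolyl chalcones: swapping the aryl ketone substituent

The compounds below may be only part of what the source reports. "The series", "measured", "known", "first", "only" and "open" are said of these compounds alone.

Measured compounds in a functional assay on RXF 393 cells (Homo sapiens) for inhibition, read by sulforhodamine B assay, with a stated time of 48 h; on this read-out lower numbers stand for higher toxicity in this test and higher numbers for lower toxicity in this test:
- compound 1, `COc1cc(-c2cc(/C=C/C(=O)c3ccc(Cl)c(Cl)c3)[nH]n2)cc(OC)c1OC`: compound 1 gives 54600 nM
- compound 2, `COc1ccc(C(=O)/C=C/c2cc(-c3cc(OC)c(OC)c(OC)c3)n[nH]2)cc1OC`: compound 2 gives 5230 nM
- compound 3, `COc1ccc(C(=O)/C=C/c2cc(-c3cc(OC)c(OC)c(OC)c3)n[nH]2)cc1`: compound 3 gives 5170 nM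

Compound 3 holds the lowest number of the three, but its step to compound 2 is within the scatter (a 1.0-fold lower number from compound 2 to compound 3 (0.01 log units; within the scatter)), so the two methoxyphenyl ketones cannot be ordered. The clear split is against compound 1: an 11-fold lower number from compound 1 to compound 3 (1.02 log units; beyond the scatter) and a 10-fold lower number from compound 1 to compound 2 (1.02 log units; beyond the scatter) both show that the dichlorinated ketone sits far toward the less toxic end.

Compound 4, `COc1cc(-c2cc(/C=C/C(=O)c3ccc(F)c(F)c3)[nH]n2)cc(OC)c1OC`, has not been measured. Relative to compound 3 the change is 3,4-difluorophenyl in place of 4-methoxyphenyl on a carbonyl carbon. For the measured compounds named here, no measured step covers fluorine directly. Going by the values given here, the steps that bear on it are the two from compound 1, where a dihalogenated ring in this place gave a large rise in the number; the methoxy-to-hydrogen step a 1.0-fold lower number from compound 2 to compound 3 (0.01 log units; within the scatter) shows that removing one methoxy alone changes little. The change to compound 4 moves the ketone aryl group back toward the pattern of compound 1, so a rise beyond the scatter is expected in this assay, probably not the full size seen for compound 1.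

The estimate for compound 4 is 20000 nM, range 6000 nM to 60000 nM, an expected step of a 3.9-fold higher number from compound 3 to compound 4 (0.59 log units; beyond the scatter).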

Compound 4, concentration lethal to 50% of the cells: 54100 nM
Compound 4: middle estimate off by 2.7-fold (0.43 log units), on the low side; measured number inside the range.
By their numbers in this assay, from the lowest: compounds 3 and 2 (each within the scatter of the next); then compounds 4 and 1 (each within the scatter of the next).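

In this assay, the 3,4-difluorophenyl group on the carbonyl carbon places compound 4 with the dichlorinated ketone and apart from both methoxyphenyl ketones (a 10-fold higher number from compound 3 to compound 4 (1.02 log units; beyond the scatter); a 10-fold higher number from compound 2 to compound 4 (1.01 log units; beyond the scatter)). Exchanging the two chlorines of the 3,4-dichlorophenyl group for fluorines gives no readable change (a 1.0-fold lower number from compound 1 to compound 4 (0.00 log units; within the scatter)), so the high number at this place is no longer tied to chlorine alone: among these four compounds, both dihalogenated rings stand apart from both methoxy-bearing rings, with no compound going against that split. Nothing measured alongside these numbers accounts for the split.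

The compounds shown leave open whether the high number needs two halogens or whether one fluorine or one chlorine on the ring would be enough, and whether the low number depends on a methoxy group or would also appear with an unsubstituted phenyl ring. Also open, from the compounds shown here alone, is how an amine, such as dimethylamino, or a carboxylic acid on this ring would behave, and whether the same split holds once the trimethoxyphenyl group on the shared core is changed.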